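A few compounds are considered here, and "the series" means these few. Any claim that something is new, unique, unknown or untested is made for them only; others in the source may bear on it.

Measured so far in an ADME assay on HepG2 cells (Homo sapiens) for cytotoxicity, read by luminescence, CellTiter-Glo and ATP content, with a stated time of 72 h; on this read-out lower numbers stand for an effect already at smaller amounts and higher numbers for an effect only at larger amounts of compound:

Compound 1, `COc1ccc(Oc2ccc3c(NCCCNCc4cccc(OC)c4O)ccnc3c2)cc1`, gives 5500 nM.
Compound 2, `COc1cccc(CNCCCNc2ccnc3cc(Cc4ccc(C#N)cc4)ccc23)c1O`, gives 7150 nM.
Compound 3, `COc1ccc(Oc2ccc3c(NCCCNCc4ccco4)ccnc3c2)cc1`, gives 5300 nM.

Compound 4, `N#Cc1ccc(Cc2ccc3c(NCCCNCc4ccco4)ccnc3c2)cc1`, has not yet been measured.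

From compound 1 to compound 2 the change is 4-cyanobenzyl in place of 4-methoxyphenoxy on an aromatic carbon, and it made a step of a 1.3-fold higher number from compound 1 to compound 2 (0.11 log units; within the scatter). The cores of compound 1 and compound 3 differ by furan-2-yl in place of 2-hydroxy-3-methoxyphenyl on a saturated chain carbon bound to an amine nitrogen, a step of a 1.0-fold lower number from compound 1 to compound 3 (0.02 log units; within the scatter). From compound 3 to compound 4 the change is 4-cyanobenzyl in place of 4-methoxyphenoxy on an aromatic carbon, the same change as before, at the same place in the shared core.

Because the step of a 1.3-fold higher number from compound 1 to compound 2 (0.11 log units; within the scatter) was small, the expected step from compound 3 to compound 4 is a 1.3-fold higher number from compound 3 to compound 4 (0.11 log units; within the scatter), of similar size. On that basis compound 4 is estimated at 6900 nM, expected to fall between 3500 nM and 13500 nM.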

Compound 4, half-maximal effective concentration: 7910 nM
For compound 4 the middle estimate is 1.1-fold (0.06 log units) below the measured one, within the range that was stated.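

In this assay, putting 4-cyanobenzyl in place of 4-methoxyphenoxy gave a 1.5-fold higher number from compound 3 to compound 4 (0.17 log units; within the scatter), which agrees with the same change on the core of compound 1: the same change on two cores in this assay, a 1.3-fold higher number (0.11 log units; within the scatter) from compound 1 to compound 2 and a 1.5-fold higher number (0.17 log units; within the scatter) from compound 3 to compound 4, 1.1-fold (0.06 log units) apart, within the scatter of two such steps. Putting furan-2-yl in place of 2-hydroxy-3-methoxyphenyl gave a 1.1-fold higher number from compound 2 to compound 4 (0.04 log units; within the scatter), and this also agrees across the two cores: the same change on two cores in this assay, a 1.0-fold lower number (0.02 log units; within the scatter) from compound 1 to compound 3 and a 1.1-fold higher number (0.04 log units; within the scatter) from compound 2 to compound 4, 1.1-fold (0.06 log units) apart, within the scatter of two such steps. The two changes therefore behave alike on both cores, but with every step inside the scatter, this does not show that a step large enough to stand out would carry over in the same way, and two cores are a narrow test.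

From the compounds shown here alone, it remains open whether a carboxylic acid or an amine on the same aromatic carbon would give a step beyond the scatter. If so, it is also open whether that step would hold on both cores.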